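The compounds below may be only part of what the source reports. "The series", "measured", "known", "first", "only" and "open" are said of these compounds alone.

Measured compounds:
- compound 1 `Fc1cccc(-c2nc3ccc(N4CCCCC4)nc3o2)c1`: 272 nM
- compound 2 `c1ccc(-c2nc3ccc(N4CCCCC4)nc3s2)cc1`: 356 nM

In an assay on isolated protein for inhibition of Amine oxidase [flavin-containing] B (Homo sapiens), read by fluorescence, with a stated time of 1 h (a higher number here means a weaker inhibitor, a lower number a stronger inhibitor), compound 2 gives 356 nM. Its only companion, compound 1, gives 272 nM in this assay, and the two numbers lie within the scatter of each other, so neither compound stands apart from the other on potency. Going by the values given here, no pair of measured compounds differs in a single place, so no measured step is available as a guide.

Compound 3 `Fc1ccc(-c2nc3ccc(N4CCCCC4)nc3s2)cc1` differs from compound 2 in one place: fluoro in place of hydrogen on an aromatic carbon. Among the compounds with values here, with no measured step to rest on, the expectation is a step of a 1.2-fold lower number from compound 2 to compound 3 (0.07 log units; within the scatter) in this assay, that is, no change beyond the scatter in either direction. Compound 3 is therefore estimated at 300 nM in this assay, with a range from 120 nM to 750 nM.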

Compound 3, half-maximal inhibitory concentration: 26.5 nM
Compound 3: middle estimate off by 11-fold (1.05 log units), on the high side; the whole stated range lies above it.
By their numbers in this assay, from the lowest: compound 3; then compounds 1 and 2 (each within the scatter of the next).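

Going by these compounds alone, the first single-place step in this set shows that the aromatic position para to a large group is far from indifferent: in this assay, the change from phenyl to 4-fluorophenyl gives a 13-fold lower number from compound 2 to compound 3 (1.13 log units; beyond the scatter). The change is small in atoms, one fluorine with no ring, no hydrogen-bond donor or acceptor and no net charge, yet the step is large and clearly beyond the scatter. Nothing measured here accounts for a step of this size.

On these data alone, it remains open whether the gain is particular to fluoro or would also appear with chloro, methoxy or an amine at the same position. As far as these compounds go, it is equally open whether fluoro at other carbons of this ring, or the same change on the core of compound 1, would give a step of similar size.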